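Dropping the Isobutyl Side Chain of Compound 2

The source may hold more compounds than are shown below. What is called first, only, known or untested is meant among the compounds shown, and "the series" means these compounds.

Among the measured compounds shown here, in an assay on HEK293 cells for binding affinity to Urotensin-2 receptor (Homo sapiens), read by radioligand binding (a lower number here means a stronger inhibitor, a higher number a weaker inhibitor), compound 2 `CC(C)C[C@H](NC(=O)c1ccc(Cl)c(Cl)c1)C(=O)N[C@H]1CCN(Cc2ccc(OCCCN(C)C)cc2)C1` gives 126 nM, the lowest of the three numbers so far. Compound 1 `CC(C)C[C@H](NC(=O)c1cc2ccccc2o1)C(=O)N[C@H]1CCN(Cc2ccc(OCCCN(C)C)cc2)C1` gives 158 nM, and a 1.3-fold lower number from compound 1 to compound 2 (0.10 log units; within the scatter). Compound 3 `CC(C)C[C@H](NC(=O)Nc1ccccc1)C(=O)N[C@H]1CCN(Cc2ccc(OCCCN(C)C)cc2)C1` gives 1000 nM; a 7.9-fold higher number from compound 2 to compound 3 (0.90 log units; beyond the scatter) and a 6.3-fold higher number from compound 1 to compound 3 (0.80 log units; beyond the scatter). Compound 4 `CN(C)CCCOc1ccc(CN2CC[C@H](NC(=O)CNC(=O)c3ccc(Cl)c(Cl)c3)C2)cc1` differs from compound 2 by hydrogen in place of isobutyl on a saturated chain carbon bound to an amide-type nitrogen and a carbonyl carbon. All three measured steps swap the group on the carbonyl carbon and leave this chain carbon untouched, so none bears directly on the change to compound 4. Since the isobutyl is removed entirely, a higher number is expected, and the step from compound 2 to compound 4 is estimated as a 5.0-fold higher number from compound 2 to compound 4 (0.70 log units; beyond the scatter). Compound 4 is therefore expected to give about 630 nM, within a range of 150 nM to 4000 nM.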

Compound 4, inhibition constant: < 10000 nM
Compound 4: a limit, no number; the forecaster's own chance of this, stated with the estimate: 10%; the middle value does not contradict the limit.
By their numbers in this assay, from the lowest: compounds 2 and 1 (each within the scatter of the next); then compound 3.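

Compound 4 gives a limit and not a number (< 10000 nM), so the step from compound 2 to compound 4 cannot be read. The compounds shown leave open how far hydrogen in place of isobutyl shifts the number in this assay on the core of compound 2.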